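Bromo to fluoro repeated across two cores, one at the limit

A few compounds are considered here, and "the series" means these few. Any claim that something is new, unique, unknown or untested is made for them only; others in the source may bear on it.

Compound 1 `Clc1ccc(-c2nnc(Nc3ccc(Br)cc3)s2)c(Cl)c1` is the reference for the first core. In a functional assay on MDA-MB-231 cells (Homo sapiens) for antiproliferative activity, read by MTT assay, with a stated time of 24 h (a higher number here means a weaker inhibitor, a lower number a stronger inhibitor), compound 1 gives 70000 nM. Compound 2 `Fc1ccc(Nc2nnc(-c3ccc(Cl)cc3Cl)s2)cc1` differs from compound 1 by fluoro in place of bromo on an aromatic carbon; in this assay compound 2 gives 130000 nM, which makes the step of a 1.9-fold higher number from compound 1 to compound 2 (0.27 log units; within the scatter). Compound 3 `Clc1ccc(OCc2nnc(Nc3ccc(Br)cc3)s2)c(Cl)c1` carries the second core; the difference between the two cores is not broken down here. For compound 3 this assay reports only a limit, > 200000 nM, and not a number. That is the limit of > 200000 nM in this assay, at which 1 of the 3 values shown sits. Compound 4 `Fc1ccc(Nc2nnc(COc3ccc(Cl)cc3Cl)s2)cc1`, not yet measured, differs from compound 3 by fluoro in place of bromo on an aromatic carbon, the same change at the same kind of place as from compound 1 to compound 2. The expected step is a step that the limit leaves unreadable from compound 3 to compound 4, because the matching change gave a 1.9-fold higher number from compound 1 to compound 2 (0.27 log units; within the scatter) and compound 3 already sits at a limit. Compound 4 is therefore estimated at 350000 nM in this assay, most likely reported again as a limit. The range expected for compound 4 runs from 150000 nM to 900000 nM.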

Compound 4, half-maximal inhibitory concentration: > 200000 nM
Compound 4: no number, only a limit; the forecaster's own chance of this, stated with the estimate: 85%; the middle value is on the limit's open side.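

Compound 3 and compound 4 are both reported only as a limit in this assay, so no step between them can be read: the limit of > 200000 nM in this assay, at which 2 of the 4 values shown sit.

The compounds shown leave open whether 4-bromophenyl to 4-fluorophenyl on the core of compound 3 behaves as it does on the core of compound 1.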